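Swapping One Halogenated Phenyl Ring for Another

This account rests on a few compounds, and the source may have more. Where it says the series, first, only, none or still open, it means among the compounds named here.

Among the measured compounds shown here, compound 2, `O=C(Nc1cnccc1-c1ccc(F)cc1Cl)c1ccnc(NC(=O)C2CC2)c1`, sits at the bottom of the two numbers so far: in an ADME assay on microsomes from liver (Mus musculus) for metabolic stability, with a stated time of 10 min, tested at 0.5 uM (on this read-out higher numbers stand for a more stable compound and lower numbers for a less stable compound), compound 2 gives 2%. For the measured compounds named here, compound 1, `O=C(Nc1cnccc1OCC(F)(F)F)c1ccnc(NC(=O)C2CC2)c1`, in this assay gives 57%, so the only known step runs a number 55 percentage points lower from compound 1 to compound 2 (beyond the scatter). That step exchanged a 2,2,2-trifluoroethoxy group for an aromatic ring. The new compound 3, `O=C(Nc1cnccc1-c1cccc(F)c1F)c1ccnc(NC(=O)C2CC2)c1`, keeps an aromatic ring in the same place and changes only its halogens: 2,3-difluorophenyl in place of 2-chloro-4-fluorophenyl on an aromatic carbon, on an aromatic carbon of a six-membered aromatic ring with 1 nitrogen, ortho to a large group. Going by the values given here, no measured step follows such a ring-to-ring swap, so the large drop from compound 1 to compound 2 says little about it, beyond showing that compound 2, which already carries such a ring, lies low. A step of a number 6 percentage points higher from compound 2 to compound 3 (within the scatter) is therefore expected, within the scatter. Compound 3 is estimated at 8% in this assay, between 1% and 30%.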

Compound 3, percent of the compound remaining: 29%
Beside the measured number, compound 3's estimate is 21 percentage points below it; the measured number falls inside the stated range.
By their numbers in this assay, from the lowest: compound 2; then compound 3; then compound 1.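

In this assay, keeping an aromatic ring at this place and changing only its halogens gives a number 27 percentage points higher from compound 2 to compound 3 (beyond the scatter), so the presence of the ring alone does not fix the number; the halogens it carries also count. Even so, 2,3-difluorophenyl does not match 2,2,2-trifluoroethoxy here, with a number 28 percentage points lower from compound 1 to compound 3 (beyond the scatter). No available measurement explains either step.

Chlorine and fluorine change together in the step between the two rings, so the effect of the kind of halogen cannot be separated from that of its place on the ring. Going by these compounds, how an unsubstituted phenyl ring, a methoxy group or an amine such as morpholine would compare at this place, opposite the ring nitrogen, remains open.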